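Shortening the Unsaturated Chain on the Carbonyl

The source may hold more compounds than are shown below. What is called first, only, known or untested is meant among the compounds shown, and "the series" means these compounds.

Of the compounds shown here, three sharing one core have been measured in a functional assay on KYSE-450 cells (Homo sapiens) for inhibition, read by MTT assay, with a stated time of 48 h; a lower number here means a stronger inhibitor, a higher number a weaker inhibitor. Compound 1 `C=C(C)C(=O)N(Cc1ccc(OC)c(O)c1)c1cc(OC)c(OC)c(OC)c1` gives 200 nM. Compound 2 `COc1ccc(CN(C(=O)CCCCCl)c2cc(OC)c(OC)c(OC)c2)cc1O` gives 770 nM. Compound 3 `COc1ccc(CN(C(=O)C=C(C)C)c2cc(OC)c(OC)c(OC)c2)cc1O` gives 280 nM, the second highest of the three numbers, close to compound 1 and further from compound 2.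

Compound 4 `C=CC(=O)N(Cc1ccc(OC)c(O)c1)c1cc(OC)c(OC)c(OC)c1` differs from compound 3 in one place: vinyl in place of 2-methylprop-1-en-1-yl on a carbonyl carbon. This shortens the unsaturated chain that sits on the carbonyl carbon.

Going by the values given here, two measured steps bear on this. From compound 1 to compound 3 the chain grew by one carbon and the number changed by a 1.4-fold higher number from compound 1 to compound 3 (0.15 log units; within the scatter), within the scatter. From compound 2 to compound 3 the saturated chlorine-bearing chain gave way to the unsaturated one and the number fell by a 2.8-fold lower number from compound 2 to compound 3 (0.44 log units; beyond the scatter). Trimming an unsaturated chain further is therefore expected to bring only a small step, a 1.3-fold lower number from compound 3 to compound 4 (0.10 log units; within the scatter), with compound 4 estimated at 220 nM, between 100 nM and 500 nM.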

Compound 4, half-maximal inhibitory concentration: 160 nM
Beside the measured number, compound 4's estimate is 1.4-fold (0.14 log units) above it, within the range that was stated.
By their numbers in this assay, from the lowest: compounds 4, 1 and 3 (each within the scatter of the next); then compound 2.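

In this assay vinyl, the shortest unsaturated group so far, sits in the same range as the two larger ones: the change on the carbonyl carbon gives a 1.8-fold lower number from compound 3 to compound 4 (0.24 log units; within the scatter) and the swap of hydrogen for methyl on the double-bonded chain carbon gives a 1.3-fold lower number from compound 1 to compound 4 (0.10 log units; within the scatter) so the size of the unsaturated group moves the number little across these three compounds. The 4-chlorobutyl chain stays apart from this set, with a 4.8-fold lower number from compound 2 to compound 4 (0.68 log units; beyond the scatter) on going to vinyl. Nothing shown explains why these groups behave this way.

As far as these compounds go, compound 2 differs from the others in both its chain and its chlorine, so it remains open whether a plain ethyl group, with no double bond and no chlorine, would sit with vinyl or with 4-chlorobutyl. Also open, from the compounds shown here alone, is how an ethynyl group, or a dimethylamino group on the end of the vinyl, would fare at this position.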